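From 2-phenylethenyl to thiophen-3-yl on a shared core

The source may hold more compounds than are shown below. What is called first, only, known or untested is meant among the compounds shown, and "the series" means these compounds.

In a functional assay on HCT-116 cells (Homo sapiens) for antiproliferative activity, with a stated time of 72 h (a lower number here means a stronger inhibitor, a higher number a weaker inhibitor), three compounds have been measured:
- compound 1 `Nc1ncnn2c([C@@H]3O[C@H](CO)[C@@H](O)[C@H]3O)cc(C#Cc3ccccc3)c12` gives 46900 nM as its value
- compound 2 `Cc1ccccc1-c1cc([C@@H]2O[C@H](CO)[C@@H](O)[C@H]2O)n2ncnc(N)c12` gives > 100000 nM as a limit of the assay
- compound 3 `Nc1ncnn2c([C@@H]3O[C@H](CO)[C@@H](O)[C@H]3O)cc(/C=C/c3ccccc3)c12` gives 4800 nM as its value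

Compound 3 is the strongest of the three, and compound 1 comes nearest to it. Compound 4 `Nc1ncnn2c([C@@H]3O[C@H](CO)[C@@H](O)[C@H]3O)cc(-c3ccsc3)c12` is still unmeasured. The change thiophen-3-yl in place of 2-phenylethenyl on an aromatic carbon puts thiophen-3-yl in place of 2-phenylethenyl on an aromatic carbon.

Three measured steps at this same place bear on it: a 9.8-fold lower number from compound 1 to compound 3 (0.99 log units; beyond the scatter) and an at least 20-fold lower number from compound 2 to compound 3 (1.31 log units; beyond the scatter) and also an at least 2.1-fold higher number from compound 1 to compound 2 (0.32 log units; beyond the scatter) show that this place matters. None of them carries thiophen-3-yl, so they give size but no direction. No step beyond the scatter is therefore expected in this assay although much larger steps stay possible. The estimated step is a 1.3-fold higher number from compound 3 to compound 4 (0.10 log units; within the scatter) for now. Compound 4 is expected at 6000 nM with an estimated range from 400 nM to 60000 nM around that middle.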

Compound 4, half-maximal inhibitory concentration: 45200 nM
Estimate against measurement, compound 4: 7.5-fold (0.88 log units) below, within the range that was stated.
By their numbers in this assay, from the lowest: compound 3; then compounds 4 and 1 (each within the scatter of the next). At a limit, above all of these: compound 2.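

In this assay, thiophen-3-yl does not keep the activity that 2-phenylethenyl gives at this position, with a 9.4-fold higher number from compound 3 to compound 4 (0.97 log units; beyond the scatter). It performs like 2-phenylethynyl, with a 1.0-fold lower number from compound 1 to compound 4 (0.02 log units; within the scatter), and is better than 2-methylphenyl, with an at least 2.2-fold lower number from compound 2 to compound 4 (0.34 log units; beyond the scatter). The value of compound 2 is a limit, not a number: the limit of > 100000 nM in this assay, at which 1 of the 4 values shown sits.

Going by these compounds, it remains open whether the double bond or the six-membered ring of 2-phenylethenyl accounts for the stronger value of compound 3. An unsubstituted phenyl group or a saturated chain such as a 2-phenylethyl group at this position would help separate the two.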